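This account rests on a few compounds, and the source may have more. Where it says the series, first, only, none or still open, it means among the compounds named here.

Compound 1 `COc1ccc(C(=O)O)cc1-c1cccc(COc2ccc3c(c2)CN(C2CCCC2)C3=O)c1` gives 100%
Compound 2 `O=C(O)c1ccc(Cl)c(-c2cccc(COc3ccc4c(c3)CN(C3CCCC3)C4=O)c2)c1` gives 100%
Compound 3 `O=C(O)c1cc(F)cc(-c2cccc(COc3ccc4c(c3)CN(C3CCCC3)C4=O)c2)c1` gives 95%

These values come from an ADME assay on a cell-free system (plasma, Rattus norvegicus) for metabolic stability, read by LC-MS, with a stated time of 1 h, at 37 degrees C, tested at 100 uM; on this read-out lower numbers stand for a less stable compound and higher numbers for a more stable compound. Compound 3 stands within the usual scatter of the other two compounds, as the steps show: a number 5 percentage points lower from compound 1 to compound 3 (within the scatter) and a number 5 percentage points lower from compound 2 to compound 3 (within the scatter). Compound 4 `Cc1ccc(C(=O)O)cc1-c1cccc(COc2ccc3c(c2)CN(C2CCCC2)C3=O)c1` has not been measured yet. It differs from compound 3 in one group: 5-carboxy-2-methylphenyl in place of 3-carboxy-5-fluorophenyl on an aromatic carbon.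

Going by the values given here, no compound with 5-carboxy-2-methylphenyl has been measured, so the closest evidence comes from its two named relatives. These are the 5-carboxy-2-methoxyphenyl of compound 1 and the 5-carboxy-2-chlorophenyl of compound 2. Exchanging one for the other gave no change at the digits printed from compound 1 to compound 2 (within the scatter). The two steps to compound 3 already shown also stay within the scatter, and no step beyond the scatter is expected here. The expected step is a number 3 percentage points higher from compound 3 to compound 4 (within the scatter). For compound 4 the estimated value is 98%, with an expected range from 88% to 100%.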

Compound 4, percent of the compound remaining: 100%
Compound 4: the middle estimate sits 2 percentage points below what was measured, within the range that was stated.
By their numbers in this assay, from the lowest: compounds 3, 1, 2 and 4 (each within the scatter of the next).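

In this assay, methyl in place of chloro gives no change at the digits printed from compound 2 to compound 4 (within the scatter) and methyl in place of methoxy gives no change at the digits printed from compound 1 to compound 4 (within the scatter) on the same ring of the shared core. Putting 5-carboxy-2-methylphenyl in place of 3-carboxy-5-fluorophenyl gives a number 5 percentage points higher from compound 3 to compound 4 (within the scatter) as well, so this exchange also stays inside the normal spread of repeat measurements. Methyl therefore joins methoxy and chloro as a third group at this place that leaves the read-out unmoved, and the four compounds cannot be told apart in this test.

As far as these compounds go, it remains open whether this holds when a methyl ester or an amide takes the place of the carboxylic acid, or when an amine takes the place of methyl. No measurement shown here offers a reason for this sameness.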